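The source may report more compounds than this note shows. Statements on the series, on what has been measured and on what is new or still open speak of the compounds shown alone.

Of the compounds shown here, two built on a shared core have been tested in a functional assay on SF-268 cells (Homo sapiens) for cytotoxicity, read by sulforhodamine B assay, with a stated time of 48 h; a lower number here means a stronger inhibitor of growth, a higher number a weaker inhibitor of growth. Compound 1 `C=C1CCC[C@H]2[C@](C)(CC3=C(O)C(=O)C=C(OC)C3=O)[C@@H](C)CC[C@]12C` gives 2700 nM, the lowest of the two numbers, which makes it the stronger growth inhibitor of the pair. Compound 2 `C=C1CCC[C@H]2[C@](C)(Cc3c(O)c(O)cc4ncoc34)[C@@H](C)CC[C@]12C` gives 24000 nM in this assay, a higher number whose gap to compound 1 lies beyond the usual scatter, so compound 2 is clearly the weaker one.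

Compound 3 `C=C1CCC[C@H]2[C@](C)(CC3=C(O)C(=O)C=C(NCC(=O)O)C3=O)[C@@H](C)CC[C@]12C` has not yet been measured. It differs from compound 1 in a single place: (carboxymethyl)amino in place of methoxy on a double-bonded ring carbon. Among the measured compounds shown here, no measured pair shows a change of this kind, so its effect cannot be read from existing numbers. The step in this assay is expected to be a 2.2-fold higher number from compound 1 to compound 3 (0.35 log units; beyond the scatter), a modest loss of growth inhibition. Compound 3 is therefore estimated to give 6000 nM, with a likely range from 1500 nM to 25000 nM.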

Compound 3, concentration for 50% growth inhibition: 9700 nM
Compound 3: middle estimate off by 1.6-fold (0.21 log units), on the low side; measured number inside the range.
By their numbers in this assay, from the lowest: compound 1; then compound 3; then compound 2.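

In this assay, among the compounds shown here, replacing methoxy with (carboxymethyl)amino on this double-bonded ring carbon gives a 3.6-fold higher number from compound 1 to compound 3 (0.56 log units; beyond the scatter) and is the first measured change at this position. The position therefore tolerates a much larger group with hydrogen-bond donors that methoxy lacks: compound 3 still has a measurable value of 9700 nM in this assay, though the swap costs some growth inhibition. No measurement on hand explains this loss.

This single swap changes the linking atom and adds the acid-bearing chain together, so it cannot show which of the two matters. A simple methylamino group would test the nitrogen link without the carboxylic acid, while a longer chain ending in the same acid would test how far the acid can sit from the ring.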